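Saturating the chain on a chalcone ether of the shared core

The source may hold more compounds than are shown below. What is called first, only, known or untested is meant among the compounds shown, and "the series" means these compounds.

Compound 1 `CC(C)=CCOc1cccc(O)c1C(=O)/C=C/c1ccc(O)cc1` carries a 3-methylbut-2-en-1-yl ether on its core. In a functional assay on MDA-MB-231 cells (Homo sapiens) for antiproliferative activity, read by sulforhodamine B assay (a higher number here means a weaker inhibitor of growth, a lower number a stronger inhibitor of growth), compound 1 gives > 30000 nM, which is a limit of the measurement rather than a number (the limit of > 30000 nM in this assay, at which 1 of the 3 values shown sits). Two neighbours give numbers. Compound 3 `CC(C)(C)CCOc1cccc(O)c1C(=O)/C=C/c1ccc(O)cc1` gives 2380 nM in this assay, and compound 2 `CC(C)(C)CCOc1cccc(O)c1C(=O)/C=C/c1ccc(C(=O)O)cc1` gives 11200 nM. The step of an at least 12-fold lower number from compound 1 to compound 3 (1.10 log units; beyond the scatter) is large, and the step of a 4.7-fold lower number from compound 2 to compound 3 (0.67 log units; beyond the scatter) is modest.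

Compound 4 `O=C(/C=C/c1ccc(O)cc1)c1c(O)cccc1OCCC1CCCCC1` is not yet measured. It differs from compound 1 in one place: cyclohexylmethyl in place of 2-methylprop-1-en-1-yl on a saturated chain carbon bound to an oxygen on an aromatic ring. For the measured compounds named here, the change resembles the one from compound 1 to compound 3, in that a saturated group without a double bond outside aromatic rings replaces the 2-methylprop-1-en-1-yl on the chain carbon bound to the ring oxygen; the entering cyclohexylmethyl is larger, with one six-membered non-aromatic ring of carbon only. The step from compound 1 to compound 3 therefore bears most directly on it, and a lowering of similar size, beyond the scatter, is expected. On that basis compound 4 is estimated at 3000 nM in this assay, with a plausible range of 1000 nM to 12000 nM, an expected step of an at least 10-fold lower number from compound 1 to compound 4 (1.00 log units; beyond the scatter).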

Compound 4, concentration for 50% growth inhibition: > 30000 nM
Compound 4: a limit, no number; the forecaster's own chance of this, stated with the estimate: 10%; middle value at least 10-fold (1.00 log units) away from the limit.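

Replacing the tert-butyl of compound 3 with cyclohexyl, on a saturated chain carbon two bonds along the chain from an oxygen on an aromatic ring, gives an at least 12-fold higher number from compound 3 to compound 4 (1.10 log units; beyond the scatter) in this assay. The earlier step to compound 3 could be read as a gain from losing the double bond, but compound 4 has no double bond in its chain either and still shows no measurable growth inhibition, so saturation alone does not account for the activity of compound 3, and what stands at the end of the chain matters as well. The result for compound 4 is a limit and not a number, as is that of compound 1, so the step between these two cannot be read: the limit of > 30000 nM in this assay, at which 2 of the 4 values shown sit.

From the compounds shown here alone, what remains open is where between tert-butyl and cyclohexyl the activity is lost, and whether a cyclopropyl or cyclopentyl group, or an open pentyl chain, at the same place would stay near compound 3 or fall to the limit. Also open, going by these compounds, is whether a piperidine ring, which carries an amine in place of the cyclohexyl carbon, would change the outcome.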